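The source may report more compounds than this note shows. Statements on the series, on what has been measured and on what is new or still open speak of the compounds shown alone.

Compound 1 `O=C1N=C(N2CCC[C@H]2C(=O)Nc2ccc3ncnc(Nc4cccc(Cl)c4)c3c2)S/C1=C/c1ccccc1Cl` and compound 2 `O=C1N=C(N2CCC[C@H]2C(=O)Nc2ccc3ncnc(Nc4cccc(Cl)c4)c3c2)S/C1=C/c1ccc(-c2ccccc2)cc1` share one core and differ only at one aryl group. In a functional assay on A549 cells (Homo sapiens) for antiproliferative activity, read by MTT assay (on this read-out lower numbers stand for stronger inhibition and higher numbers for weaker inhibition), compound 1 reaches only a limit of the assay, > 50000 nM. Compound 2 gives 24200 nM. Among the measured compounds shown here, the single measured step, an at least 2.0-fold lower number from compound 1 to compound 2 (0.31 log units; beyond the scatter), concerns a different change from the one now considered, and the picture is shaped by the limit of > 50000 nM in this assay, at which 1 of the 2 values shown sits. Compound 3 `O=C1N=C(N2CCC[C@H]2C(=O)Nc2ccc3ncnc(Nc4cccc(Cl)c4)c3c2)S/C1=C/c1ccccc1[N+](=O)[O-]` differs from compound 1 by nitro in place of chloro on an aromatic carbon. For the measured compounds named here, since no measured step covers this change, compound 3 is expected to show a number no higher from compound 1 to compound 3 (the limit leaves the size open), no clear direction being supported. The estimated value of compound 3 is 50000 nM, ranging from 15000 nM to 150000 nM.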

Compound 3, half-maximal inhibitory concentration: > 50000 nM
Compound 3 was reported as a limit; the forecaster's own chance of this, stated with the estimate: 50%; the middle value lies on the limit itself.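

In this assay compound 3 gives > 50000 nM, which is a limit of the assay and not a number. Set against the 4-phenylphenyl group, 2-nitrophenyl gives an at least 2.0-fold higher number from compound 2 to compound 3 (0.31 log units; beyond the scatter), so nitro, like chloro on this aromatic carbon, yields no readable value here. The step between chloro and nitro cannot be read, because both compounds rest at the limit: the limit of > 50000 nM in this assay, at which 2 of the 3 values shown sit.

The compounds shown leave open how far chloro and nitro truly differ. They also leave open whether an amine or a carboxylic acid on this aromatic carbon would bring the number under the limit.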